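The source may report more compounds than this note shows. Statements on the series, on what has been measured and on what is new or still open speak of the compounds shown alone.

Compound 2 `COc1ccc(-n2ccc(=O)c(C(=O)Nc3ccc(Oc4ccnc5[nH]ccc45)cc3)n2)cc1` gives 50800 nM in a functional assay on HepG2 cells (Homo sapiens) for cytotoxicity, read by MTT assay, with a stated time of 72 h (on this read-out lower numbers stand for stronger inhibition and higher numbers for weaker inhibition), the highest of the two numbers; the nearest is compound 1 `O=C(Nc1ccc(Oc2ccnc3[nH]ccc23)cc1)c1nn(-c2ccc(Cl)cc2)ccc1=O`, which gives 19500 nM in this assay. Compound 3 `O=C(Nc1ccc(Oc2ccnc3[nH]ccc23)cc1)c1nn(-c2ccc(Br)cc2)ccc1=O` is not yet measured; it differs from compound 2 by bromo in place of methoxy on an aromatic carbon. Among the measured compounds shown here, the one step that bears on this is a 2.6-fold higher number from compound 1 to compound 2 (0.42 log units; beyond the scatter), in which methoxy replaced chloro; the present change again swaps the methoxy for a halogen, here bromo. A step of about that size in the opposite direction is therefore expected for compound 3, a 2.5-fold lower number from compound 2 to compound 3 (0.40 log units; beyond the scatter). The estimate for compound 3 in this assay is 20000 nM, with a range from 8000 nM to 50000 nM.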

Compound 3, half-maximal inhibitory concentration: 4280 nM
Beside the measured number, compound 3's estimate is 4.7-fold (0.67 log units) above it; the whole stated range lies above it.
By their numbers in this assay, from the lowest: compound 3; then compound 1; then compound 2.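

In this assay, the two halogens at this aromatic carbon, para to a large group, are not interchangeable: bromo in place of chloro gives a step beyond the scatter (a 4.6-fold lower number from compound 1 to compound 3 (0.66 log units; beyond the scatter)). Bromo in place of methoxy gives a large step (a 12-fold lower number from compound 2 to compound 3 (1.07 log units; beyond the scatter)), so the order from the lowest number runs bromo, chloro, methoxy. Nothing measured here accounts for that order.

Still open, as far as these compounds go, is where iodo, fluoro, an amine or a carboxylic acid at this carbon would fall. Also open, from the compounds shown here alone, is whether this order holds on any other core.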